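Swapping the halogenated phenyl on a weakly cytotoxic amide

A few compounds are considered here, and "the series" means these few. Any claim that something is new, unique, unknown or untested is made for them only; others in the source may bear on it.

Two compounds share one core and differ in the halogen pattern of two phenyl rings. Compound 1 `Cn1ccc2c(Oc3ccc(NC(=O)c4nn(-c5ccc(Cl)c(F)c5)ccc4=O)cc3)ccnc21` carries a 4-chloro-3-fluorophenyl on the ring nitrogen; in a functional assay on MCF7 cells (Homo sapiens) for cytotoxicity, read by MTT assay, with a stated time of 72 h (on this read-out higher numbers stand for weaker inhibition and lower numbers for stronger inhibition), compound 1 gives 16800 nM. Compound 2 `Cn1ccc2c(Oc3ccc(NC(=O)c4nn(-c5ccc(Br)cc5F)ccc4=O)cc3F)ccnc21` carries a 4-bromo-2-fluorophenyl there and an extra fluorine on the central ring; in this assay compound 2 gives 14100 nM. Compound 2 holds the lowest of the two numbers, yet its neighbour, compound 1, sits within the scatter, so the two cannot be told apart on these data.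

Compound 3 `Cn1ccc2c(Oc3ccc(NC(=O)c4nn(-c5ccc(Cl)c(F)c5)ccc4=O)cc3F)ccnc21` has not been measured in this assay. It differs from compound 2 in one place: 4-chloro-3-fluorophenyl in place of 4-bromo-2-fluorophenyl on an aromatic nitrogen. Both halogenated phenyl groups already appear among the measured compounds and both give similar weak inhibition, so no step beyond the scatter is expected from compound 2 to compound 3, as a 1.1-fold higher number from compound 2 to compound 3 (0.03 log units; within the scatter) states. Compound 3 is therefore estimated to give 15000 nM in this assay, with a range from 7000 nM to 32000 nM.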

Compound 3, half-maximal inhibitory concentration: 16600 nM
Estimate against measurement, compound 3: 1.1-fold (0.04 log units) below; measured number inside the range.
By their numbers in this assay, from the lowest: compounds 2, 3 and 1 (each within the scatter of the next).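

Compound 3 separates the two differences between compound 1 and compound 2, which that earlier pair could not do because it changed both places at once. With the chloro-fluoro ring held constant, adding fluoro in place of hydrogen on an aromatic carbon gives a 1.0-fold lower number from compound 1 to compound 3 (0.01 log units; within the scatter) in this assay, while with that fluoro held constant, placing 4-chloro-3-fluorophenyl in place of 4-bromo-2-fluorophenyl on the aromatic nitrogen gives a 1.2-fold higher number from compound 2 to compound 3 (0.07 log units; within the scatter), so neither single change can be told from repeat-measurement noise here. Nothing shown explains why these numbers stay so close.

On these data alone, all three compounds carry a halogenated phenyl on the aromatic nitrogen, so it remains open whether a phenyl bearing an amine or a carboxylic acid, or a simple alkyl chain there, would shift the number beyond the scatter. The aromatic carbon is likewise shown only with hydrogen or fluoro, which leaves groups such as methoxy or nitrile open, and these readings come from a single cell line.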